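Replacing phenyl with a trifluoromethylphenoxymethyl arm in compound 4

A few compounds are considered here, and "the series" means these few. Any claim that something is new, unique, unknown or untested is made for them only; others in the source may bear on it.

In a functional assay on CHO cells for antagonist activity at prostaglandin E2 receptor EP4 subtype (Homo sapiens), read by calcium flux, with a stated time of 15 min (a lower number here means a stronger inhibitor, a higher number a weaker inhibitor), compound 3 `C[C@H](NC(=O)c1c(-c2ccccc2)nnn1Cc1ccccc1)c1ccc(C(=O)O)cc1` gives 647 nM, the only numeric result among the three measured compounds. Compound 1 `CCCc1c(C(=O)N[C@@H](C)c2ccc(C(=O)O)cc2)nnn1Cc1ccc(C(F)(F)F)cc1` reaches only the limit of the assay, > 10000 nM. Compound 2 `CCc1nnn(Cc2ccc(C(F)(F)F)cc2)c1C(=O)N[C@@H](C)c1ccc(C(=O)O)cc1` likewise reaches only the limit, > 10000 nM. Within the data shown here, both of these values sit at the limit of > 10000 nM in this assay, at which 2 of the 3 values shown sit, so no measured step between compounds is available to anchor a prediction. Compound 4 `C[C@H](NC(=O)c1c(-c2ccccc2)nnn1CCOc1ccc(C(F)(F)F)cc1)c1ccc(C(=O)O)cc1` differs from compound 3 by (4-(trifluoromethyl)phenoxy)methyl in place of phenyl on a saturated chain carbon bound to an aromatic nitrogen. Among the measured compounds shown here, with no measured step to guide the direction, the author expects the step from compound 3 to compound 4 to be small, a 1.3-fold lower number from compound 3 to compound 4 (0.11 log units; within the scatter), lying within the usual scatter. Compound 4 is therefore estimated at 500 nM, with a range from 150 nM to 2500 nM.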

Compound 4, half-maximal inhibitory concentration: 49.1 nM
The estimate for compound 4 lay 10-fold (1.01 log units) above the measured number, outside the stated range (below it).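

On a saturated chain carbon bound to an aromatic nitrogen, (4-(trifluoromethyl)phenoxy)methyl in place of phenyl gives a 13-fold lower number from compound 3 to compound 4 (1.12 log units; beyond the scatter). Among these compounds, this shows that the position accepts the larger arm and that the number responds strongly to the change, which the earlier compounds, with no step readable among them, could not show: the limit of > 10000 nM in this assay, at which 2 of the 4 values shown sit. Nothing measured here bears on the cause of this step. Which part of the arm carries the gain stays open: the trifluoromethyl, the oxygen or the chain. Also open, as far as these compounds go, is whether an amine or a nitrile in place of trifluoromethyl would keep it.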